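The source may report more compounds than this note shows. Statements on the series, on what has been measured and on what is new or still open speak of the compounds shown alone.

Measured so far in a physicochemical assay for lipophilicity; on this read-out higher numbers stand for higher lipophilicity and lower numbers for lower lipophilicity:
- compound 1 `CNC(=O)c1cc(C(=O)N[C@H]2CC[C@H](O)CC2)c([C@@H](C)c2cccc(C)c2)o1`: 3.3
- compound 2 `CNC(=O)c1cc(C(=O)N[C@H]2CC[C@H](O)CC2)c([C@@H](C)c2ccc(Cl)cc2)o1`: 3.5

For the measured compounds named here, compound 2 stands within the scatter of compound 1, the only other measured member of the series. Next comes compound 3 `CNC(=O)c1cc(C(=O)N[C@H]2CC[C@H](O)CC2)c([C@@H](C)c2ccccc2)o1`, with hydrogen in place of chloro on an aromatic carbon, so that 4-chlorophenyl becomes phenyl.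

Going by the values given here, one measured step bears on this change, and only indirectly: 4-chlorophenyl in place of 3-methylphenyl gave a number 0.20 log units higher from compound 1 to compound 2 (within the scatter). That step exchanges one substituent for another, whereas compound 3 has none at all on its phenyl, so the series holds no direct measure of this change. Both substituted references are therefore used as a guide, with compound 1 at 3.3 and compound 2 at 3.5, and compound 3 is expected to fall under both in this assay. The expected step is a number 0.60 log units lower from compound 2 to compound 3 (beyond the scatter). The estimate for compound 3 is 2.9, with an expected range of 2.6 to 3.2.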

Compound 3, distribution coefficient: 2.8
Compound 3: middle estimate off by 0.10 log units, on the high side; the measured number falls inside the stated range.
By their numbers in this assay, from the lowest: compound 3; then compounds 1 and 2 (each within the scatter of the next).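

In this assay the unsubstituted phenyl gives the series its first reference point for this position: a number 0.70 log units lower from compound 2 to compound 3 (beyond the scatter) and a number 0.50 log units lower from compound 1 to compound 3 (beyond the scatter) both lie beyond the scatter, whereas the earlier exchange, a number 0.20 log units higher from compound 1 to compound 2 (within the scatter) stayed within it. Among these three compounds, therefore, the presence of a substituent on the phenyl separates on this read-out, while chloro and methyl, which also sit on different ring carbons, remain unresolved from each other. Nothing measured here explains the size of either step.

Chloro and methyl are each seen at only one ring carbon, so these compounds cannot separate the identity of the substituent from its place, and 3-chlorophenyl or 4-methylphenyl would be needed to do so. Also open, on these data alone, is where fluoro, methoxy, a carboxylic acid or an amine on the aromatic carbon para to a large group would stand relative to compound 3 at 2.8 on this read-out.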